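This account rests on a few compounds, and the source may have more. Where it says the series, first, only, none or still open, it means among the compounds named here.

Of the compounds shown here, three have been measured in a functional assay on Hep 3B2 cells (Homo sapiens) for antiproliferative activity, read by MTT assay, with a stated time of 24 h, tested at 0.14 ug/mL; a lower number here means a weaker effect, a higher number a stronger effect of the compound at the concentration tested. Compound 1 `Cc1c(C(=O)Nc2c(F)cc(-c3cccc(F)c3)cc2F)nc2ccc(OC(F)(F)F)cc2c1O` gives 2.01%, compound 2 `Cc1c(C(=O)Nc2c(F)cc(-c3cccc(F)c3)cc2F)nc2ccc(C(F)(F)F)cc2c1O` gives 2.65%, and compound 3 `Cc1c(C(=O)Nc2ccc(-c3ccccc3)cc2)nc2ccccc2c1O` gives 3.02%. Compound 2 stands second of these three numbers, yet all three lie within the scatter of one another, so none can be called stronger or weaker. Going by the values given here, the single measured step, a number 0.6 percentage points higher from compound 1 to compound 2 (within the scatter), concerns a change on a different part of the shared core. Compound 4 `Cc1c(C(=O)Nc2c(F)cc(-c3cccc(F)c3)cc2F)nc2ccc(C(F)(F)F)cc2c1C(=O)O` differs from compound 2 by carboxy in place of hydroxy on an aromatic carbon. Among the compounds with values here, no measured step touches the hydroxy group, so the data give no direction for this change; the expected step is a number 0.4 percentage points higher from compound 2 to compound 4 (within the scatter), none beyond the scatter. Compound 4 is therefore estimated at 3%, between 0% and 10%.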

Compound 4, a percentage reported as inhibition, at one concentration (the size of the read-out at that concentration, not a potency): 2.13%
The estimate for compound 4 lay 0.9 percentage points above the measured number; measured number inside the range.
By their numbers in this assay, from the lowest: compounds 1, 4, 2 and 3 (each within the scatter of the next).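

In this assay, going by these compounds alone, this is the first measured change at the position opposite the ring nitrogen: carboxy in place of hydroxy gives a number 0.5 percentage points lower from compound 2 to compound 4 (within the scatter) and so leaves the read-out within the scatter. At this single concentration, the hydroxy group therefore shows no measurable advantage over carboxy, although compound 2 and compound 4 both give small numbers. No measured evidence bears on this result.

On these data alone, whether an amine or a methoxy group here would lift the number beyond the scatter remains open. So does whether hydroxy and carboxy would still match at another concentration.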